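This account rests on a few compounds, and the source may have more. Where it says the series, first, only, none or still open, it means among the compounds named here.

Measured in a functional assay on DU-145 cells (Homo sapiens) for cytotoxicity, read by MTT assay; on this read-out higher numbers stand for weaker inhibition and lower numbers for stronger inhibition:
- compound 1 `COc1ccc(CSc2nnc([C@@H](C)c3ccc4cc(OC)ccc4c3)n2-c2ccc(Cl)cc2)cc1`: 72600 nM
- compound 2 `COc1ccc2cc([C@H](C)c3nnc(SCc4ccc(C)cc4)n3-c3ccc(F)cc3)ccc2c1`: 44300 nM
- compound 3 `COc1ccc2cc([C@H](C)c3nnc(SCc4ccc(F)cc4)n3-c3ccc(F)cc3)ccc2c1`: 60200 nM

Compound 3, at 60200 nM, lies within the scatter of both other compounds, so the three values give no order among themselves. The next step leads to compound 4 `COc1ccc(CSc2nnc([C@@H](C)c3ccc4cc(OC)ccc4c3)n2-c2ccc(F)cc2)cc1`, which is unmeasured. The change is methoxy in place of fluoro on an aromatic carbon, turning 4-fluorobenzyl into 4-methoxybenzyl.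

Among the compounds with values here, only one measured step touches this group: a 1.4-fold higher number from compound 2 to compound 3 (0.13 log units; within the scatter), where fluoro replaced methyl. Methoxy itself has not been compared directly with fluoro on an otherwise identical compound. Compound 1 already carries the (4-methoxybenzyl)sulfanyl group, but it differs elsewhere, and it gives 72600 nM. Neither observation points to a real shift, so no step beyond the scatter is expected in this assay. The estimated result is a 1.0-fold lower number from compound 3 to compound 4 (0.00 log units; within the scatter). For compound 4 the expected value is 60000 nM, with an estimated range of 30000 nM to 115000 nM.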

Compound 4, half-maximal inhibitory concentration: <= 400000 nM
Compound 4: a limit, no number; the forecaster's own chance of this, stated with the estimate: 10%; the middle value does not contradict the limit.
By their numbers in this assay, from the lowest: compounds 2, 3 and 1 (each within the scatter of the next).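

In this assay compound 4 gives <= 400000 nM, a limit and not a number; the steps from compound 1, compound 2 and compound 3 to compound 4 cannot be read. The compounds shown leave open whether 4-methoxybenzyl in place of 4-fluorobenzyl, or fluoro in place of chloro, shifts the number at all.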